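A few compounds are considered here, and "the series" means these few. Any claim that something is new, unique, unknown or untested is made for them only; others in the source may bear on it.

In a physicochemical assay for solubility, with a stated time of 18 h, at pH 7.4 (a higher number here means a more soluble compound, a lower number a less soluble compound), compound 1 `COc1ccc(F)cc1CNCCCNc1ccnc2cc(Cc3ccc(C#N)cc3)ccc12` gives 4200 nM. Compound 2 `FC(F)(F)c1ccc(-c2ccc3c(NCCCNCc4ccco4)ccnc3c2)cc1` gives 32000 nM and compound 3 `c1ccc(CCc2ccc3c(NCCCNCc4ccco4)ccnc3c2)cc1` gives 4200 nM. Compound 1 is level with compound 3 at the digits shown, the two together the lowest of the three numbers, while the only measured step, a 7.6-fold lower number from compound 2 to compound 3 (0.88 log units; beyond the scatter), places the value of compound 1 furthest from that of compound 2. Compound 4 `COc1ccc(Oc2ccc3c(NCCCNCc4cc(F)ccc4OC)ccnc3c2)cc1` carries 4-methoxyphenoxy in place of 4-cyanobenzyl on an aromatic carbon. Among the compounds with values here, no measured step covers this exchange; the one step that exists swaps a different aryl group on the shared core and shows that such a swap can move this assay by a modest amount, without fixing the direction here. Compound 4 is therefore expected near compound 1, estimated at 6000 nM with a range of 1500 nM to 25000 nM. The expected step is a 1.4-fold higher number from compound 1 to compound 4 (0.15 log units; within the scatter).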

Compound 4, solubility: 14500 nM
For compound 4 the middle estimate is 2.4-fold (0.38 log units) below the measured one; the measured number falls inside the stated range.
By their numbers in this assay, from the lowest: compounds 1 and 3 (each within the scatter of the next); then compound 4; then compound 2.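

In this assay, within the data shown here, 4-methoxyphenoxy in place of 4-cyanobenzyl gives a 3.5-fold higher number from compound 1 to compound 4 (0.54 log units; beyond the scatter), the first step at this position with compound 1's side chain held constant. The two groups match in heavy-atom count and each carries one six-membered aromatic ring of carbon only, yet the step lies beyond the scatter. Nothing available bears on the reason for this step. Both the linking atom and the end group change together, so a 4-cyanophenoxy or 4-methoxybenzyl group would be needed to separate them. On these data alone, how an amine or carboxylic acid at this place would read remains open.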